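This account rests on a few compounds, and the source may have more. Where it says the series, first, only, none or still open, it means among the compounds named here.

Measured so far in a functional assay on HCT-116 cells (Homo sapiens) for inhibition, read by MTT assay, with a stated time of 48 h; on this read-out lower numbers stand for stronger inhibition and higher numbers for weaker inhibition:
- compound 1, `COc1ccc(N(C)c2nc(C)nc3ccccc23)cc1OCCCCCC[Se]C#N`: compound 1 gives 6180 nM
- compound 2, `COc1ccc(N(C)c2nc(C)nc3ccccc23)cc1C(=O)OCCCC[Se]C#N`: compound 2 gives 662 nM
- compound 3, `COc1ccc(N(C)c2nc(C)nc3ccccc23)cc1OCCCC[Se]C#N`: compound 3 gives 512 nM

Compound 3 and compound 1 share a core and differ only in the chain end: a group of 5 heavy atoms (3 carbon, 1 nitrogen, 1 selenium; no ring) in place of a group of 3 heavy atoms (1 carbon, 1 nitrogen, 1 selenium; no ring), on a saturated chain carbon, four bonds along the chain from an oxygen on an aromatic ring. This lengthening made a 12-fold higher number from compound 3 to compound 1 (1.08 log units; beyond the scatter), the one large move in the set so far.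

Compound 2 differs from compound 3 in the core itself: a group of 10 heavy atoms (6 carbon, 1 nitrogen, 2 oxygen, 1 selenium; no ring) in place of a group of 8 heavy atoms (5 carbon, 1 nitrogen, 1 oxygen, 1 selenium; no ring), on an aromatic carbon. The two values sit close together, a 1.3-fold lower number from compound 2 to compound 3 (0.11 log units; within the scatter), so on this read-out the two cores behave alike with the shorter chain.

Compound 4, `COc1ccc(N(C)c2nc(C)nc3ccccc23)cc1C(=O)OCCCCCC[Se]C#N`, has not been measured. It stands to compound 2 as compound 1 stands to compound 3: a group of 5 heavy atoms (3 carbon, 1 nitrogen, 1 selenium; no ring) in place of a group of 3 heavy atoms (1 carbon, 1 nitrogen, 1 selenium; no ring), on a saturated chain carbon, four bonds along the chain from an oxygen next to a carbonyl group. The surroundings of the place are not identical. In compound 3 the chain carbon is four bonds along the chain from an oxygen on an aromatic ring, whereas in compound 2 it is four bonds along the chain from an oxygen next to a carbonyl group. Going by the values given here, it is therefore the same kind of change, not the same change, and the single earlier instance is the only guide.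

Among the compounds with values here, the expected step is a 9.1-fold higher number from compound 2 to compound 4 (0.96 log units; beyond the scatter), resting on the weakening seen as a 12-fold higher number from compound 3 to compound 1 (1.08 log units; beyond the scatter), with a wide range because only that one step is known. In this assay compound 4 is expected to give about 6000 nM. The estimate for compound 4 is expected to fall between 2000 nM and 18000 nM.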

Compound 4, half-maximal inhibitory concentration: 1990 nM
Estimate against measurement, compound 4: 3.0-fold (0.48 log units) above; measured number outside the range, below it.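

In this assay the group of 5 heavy atoms in place of the group of 3 heavy atoms again weakens inhibition, with a 3.0-fold higher number from compound 2 to compound 4 (0.48 log units; beyond the scatter), so the direction of the change carries over to the core of compound 2. The size of the change does not carry over, and the step on one core cannot simply be transferred to the other as a number: the same change on two cores in this assay, a 12-fold higher number (1.08 log units; beyond the scatter) from compound 3 to compound 1 and a 3.0-fold higher number (0.48 log units; beyond the scatter) from compound 2 to compound 4, 4.0-fold (0.60 log units) apart, beyond the scatter of two such steps. Two pairs show that the direction agrees on these two cores, but they do not explain the difference in size, nor do they establish a rule for any further core.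

The compounds shown leave open how the numbers run along the chain on either core, since only these two chain ends appear, and a chain of intermediate length or a longer chain could show whether the rise is steady or sets in abruptly. They also leave open how much of the activity depends on the selenium and nitrile end of the chain, which a sulfur atom in place of selenium or a carboxylic acid at the chain end would begin to address.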